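From 2-phenylethenyl to pentyl on a carbonyl carbon

The source may report more compounds than this note shows. Statements on the series, on what has been measured and on what is new or still open speak of the compounds shown alone.

The compounds share one core and differ in the group on a carbonyl carbon. In a functional assay on NCI-H460 cells (Homo sapiens) for cytotoxicity, read by MTT assay, with a stated time of 48 h (on this read-out lower numbers stand for stronger inhibition and higher numbers for weaker inhibition), compound 1 `C=C1C(=O)O[C@H]2CC3=C[C@H](C/C(C)=C/[C@@H](OC(=O)c4ccc(-c5ccccc5)cc4)[C@H]12)OC3=O` gives 3500 nM. Compound 2 `C=C1C(=O)O[C@H]2CC3=C[C@H](C/C(C)=C/[C@@H](OC(=O)/C=C/c4ccccc4)[C@H]12)OC3=O` stands at > 10000 nM in this assay, and this reading is a limit and not a number. Compound 2 therefore has no measured position of its own.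

The next structure is compound 3 `C=C1C(=O)O[C@H]2CC3=C[C@H](C/C(C)=C/[C@@H](OC(=O)CCCCC)[C@H]12)OC3=O`, which differs from compound 2 as follows: pentyl in place of 2-phenylethenyl on a carbonyl carbon. In words, pentyl takes the place of 2-phenylethenyl on a carbonyl carbon. Within the data shown here, no measured pair isolates a change of this kind, so the expectation is loose. A modest move toward lower numbers is expected, possibly none beyond the scatter. That direction rests on compound 1 at 3500 nM, which shows that this core can give a measured number with a different group at this place. The expected change is estimated as an at least 1.1-fold lower number from compound 2 to compound 3 (0.04 log units; that floor lies within the scatter). For compound 3 the estimated value is 9000 nM, with an expected range from 3500 nM to 25000 nM.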

Compound 3, half-maximal inhibitory concentration: 5900 nM
For compound 3 the middle estimate is 1.5-fold (0.18 log units) above the measured one, within the range that was stated.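

In this assay, the change to pentyl on a carbonyl carbon gives an at least 1.6-fold lower number from compound 2 to compound 3 (0.22 log units; that floor lies within the scatter), and this step is only a floor because compound 2 is read at a limit of the assay and not at a number: the limit of > 10000 nM in this assay, at which 1 of the 3 values shown sits.

Compound 3 shows that the group at this place needs no ring for the shared core to give a measured number, since pentyl has none and 2-phenylethenyl has one six-membered aromatic ring. In this assay compound 1 gives 3500 nM and compound 3 gives 5900 nM, two values within the scatter of each other, so the ring-bearing group of compound 1 and the open chain of compound 3 cannot be told apart on these numbers.

As far as these compounds go, the true position of compound 2 stays open, and with it the real size of the step to pentyl, which may or may not exceed the scatter. Also open, from the compounds shown here alone, is how the read-out responds to a longer chain such as octyl, or to a pentyl chain ending in an amine or a carboxylic acid.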